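Trading Methoxy for Bromo on the Core of Compound 1

The source may hold more compounds than are shown below. What is called first, only, known or untested is meant among the compounds shown, and "the series" means these compounds.

Of the compounds shown here, three have been measured in an assay on HEK293 cells with Neuronal acetylcholine receptor; alpha4/beta2 (Homo sapiens) as the target, read by FLIPR and calcium flux; on this read-out higher numbers stand for larger maximal responses and lower numbers for smaller maximal responses. Compound 1 `COc1cc(N2CCCNCC2)cnc1Cl` gives 116% in this assay, the highest of the three numbers. Compound 2 `C=COc1cc(N2CCCNCCC2)cnc1Br` gives 90% in this assay, a value that sits beyond the scatter below that of compound 1. Compound 3 `C/C=C\Oc1cncc(N2CCCNCC2)c1` gives 45% in this assay, the lowest of the three and the furthest from compound 1. Within the data shown here, compounds 2 and 3 each differ from compound 1 in more than one place, so no single step between measured compounds is available, and their values tell only where they fall relative to one another.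

Compound 4 `Clc1ncc(N2CCCNCC2)cc1Br` has not yet been measured in this assay. It differs from compound 1 in one place only: bromo in place of methoxy on an aromatic carbon. Among the measured compounds shown here, no measured pair shows what a bromo in place of a methoxy on an aromatic carbon does here. The expectation therefore rests on compound 1 alone, which gives 116%. A modest downward step is expected, a number 21 percentage points lower from compound 1 to compound 4 (beyond the scatter), one that could still lie within the usual scatter. Compound 4 is therefore estimated to reach 95% in this assay, with a range from 60% to 130%.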

Compound 4, largest response reached (reported as efficacy), in percent of the reference or control that the assay uses: 85%
The estimate for compound 4 lay 10 percentage points above the measured number; the measured number falls inside the stated range.
By their numbers in this assay, from the lowest: compound 3; then compounds 4 and 2 (each within the scatter of the next); then compound 1.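

Among these compounds, compound 4 supplies the first comparison that changes one place only: in this assay, bromo in place of methoxy on an aromatic carbon, ortho to a chloro group and two atoms from the ring nitrogen, gives a number 31 percentage points lower from compound 1 to compound 4 (beyond the scatter), a large step. The maximal response therefore depends on which of these two groups occupies this position, although the exchange does not remove the response, as compound 4 still gives 85% in this assay. The compounds shown offer no measurement that explains why the response falls with this exchange.

As far as these compounds go, with only methoxy and bromo compared at this position, it remains open how an amino group, a nitrile or a longer ether chain such as ethoxy would fare there, and so whether the response follows any trend across groups or is particular to this pair. From the compounds shown here alone, it is also open whether the same exchange would give a similar step on a compound other than compound 1, since this single pair shares one core and keeps the chloro group throughout.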